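This account rests on a few compounds, and the source may have more. Where it says the series, first, only, none or still open, it means among the compounds named here.

Measured so far in a physicochemical assay for lipophilicity, read by HPLC, at pH 7.5; a higher number here means a more lipophilic compound, a lower number a more polar compound 
Compound 1 `CC[C@@H](Nc1c(C#N)c(-c2ccc(-c3cccc(Cl)c3F)cc2)nc2cnccc12)C(N)=O` gives 3.1 
Compound 2 `CC[C@@H](Nc1c(C#N)c(-c2ccc(Br)cc2)nc2cnccc12)C(=O)O` gives 1.6 

Compound 1 holds the higher of these two numbers, and the gap to compound 2 lies beyond the usual scatter. Compound 3 `CC[C@@H](Nc1c(C#N)c(-c2ccc(-c3cccnc3C)cc2)nc2cnccc12)C(N)=O` has not been measured yet. It carries 2-methylpyridin-3-yl in place of the 3-chloro-2-fluorophenyl of compound 1, on an aromatic carbon para to a large group 2-methylpyridin-3-yl in place of 3-chloro-2-fluorophenyl on an aromatic carbon and otherwise keeps the same structure. For the measured compounds named here, no measured pair shows this swap, so the expectation rests on the structural change alone: an estimated fall beyond the scatter, a number 0.90 log units lower from compound 1 to compound 3 (beyond the scatter) in this assay for this swap. Compound 3 is estimated at 2.2 with 1.7 to 2.7 as the expected range.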

Compound 3, distribution coefficient: 1.9
Compound 3: the middle estimate sits 0.30 log units above what was measured, within the range that was stated.
By their numbers in this assay, from the lowest: compounds 2 and 3 (each within the scatter of the next); then compound 1.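

For the compounds shown here, compound 1 and compound 3 give the first measured swap at this position: on an aromatic carbon para to a large group, 2-methylpyridin-3-yl in place of 3-chloro-2-fluorophenyl gives a number 1.20 log units lower from compound 1 to compound 3 (beyond the scatter) in this assay. The rest of the structure is unchanged, so this one group accounts for the whole step. Nothing available ties the step to any single feature of the swap. Open, from the compounds shown here alone, is where a plain phenyl or a pyridin-3-yl without the methyl would fall in this assay, which would separate the effect of the methyl from that of the ring nitrogen.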